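The source may report more compounds than this note shows. Statements on the series, on what has been measured and on what is new or still open speak of the compounds shown alone.

Measured in a functional assay on MDA-MB-231 cells (Homo sapiens) for inhibition, read by MTT assay, with a stated time of 72 h (on this read-out lower numbers stand for stronger inhibition and higher numbers for weaker inhibition), are these compounds:

Compound 1 `CN(C)c1ccc(-c2cc(C(=O)N3CCC4(CC3)CC(=O)c3nn(C(C)(C)C)cc3O4)c3ccccc3n2)cc1` gives > 10000 nM as a limit of the assay
Compound 2 `CC(C)(C)n1cc2c(n1)C(=O)CC1(CCN(C(=O)c3cc(-c4ccccn4)nc4ccccc34)CC1)O2` gives 8100 nM as a measured number
Compound 3 `COc1cc(C(=O)N2CCC3(CC2)CC(=O)c2nn(C(C)(C)C)cc2O3)c2ccccc2n1` gives > 10000 nM as a limit of the assay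

Compound 3 therefore has no number, and it stands at the limit of > 10000 nM in this assay, at which 2 of the 3 values shown sit, among the values shown. Compound 4 `CC(C)Oc1cc(C(=O)N2CCC3(CC2)CC(=O)c2nn(C(C)(C)C)cc2O3)c2ccccc2n1` differs from compound 3 in one place (isopropyl in place of methyl on an oxygen on an aromatic ring). Here isopropyl stands in place of methyl on an oxygen on an aromatic ring, turning methoxy into isopropoxy. Among the measured compounds shown here, no measured step covers this change directly. The nearest are an at least 1.2-fold higher number from compound 2 to compound 3 (0.09 log units; that floor lies within the scatter) for methoxy in place of pyridin-2-yl and a step that the two limits leave unreadable from compound 1 to compound 3 for methoxy in place of 4-(dimethylamino)phenyl on an aromatic carbon. Neither shows a readable step beyond the scatter, so none beyond the scatter is expected in this assay for this smaller change. The expected step is a number no higher from compound 3 to compound 4 (the limit leaves the size open) as an estimate. The estimated value for compound 4 is 10000 nM with an expected range from 5000 nM to 20000 nM and it may again appear only as a limit.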

Compound 4, half-maximal inhibitory concentration: > 10000 nM
Compound 4 was reported as a limit (the forecaster's own chance of this, stated with the estimate: 70%); the middle value lies on the limit itself.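

With isopropoxy in place of methoxy, compound 4 gives > 10000 nM in this assay, a limit and not a number, so a second group on this oxygen also yields no measured value. The steps to compound 4 from compound 1 and from compound 3 cannot be read, and the one that can be read is an at least 1.2-fold higher number from compound 2 to compound 4 (0.09 log units; that floor lies within the scatter). Compound 2 remains the only compound shown with a measured number, and compound 4 joins the others at the limit: the limit of > 10000 nM in this assay, at which 3 of the 4 values shown sit.

The compounds shown leave open whether a longer chain on the oxygen, or an amine or a carboxylic acid on this aromatic carbon, would give a measured number. On these data alone, how far compound 1, compound 3 and compound 4 lie from one another also stays unknown.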